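A few compounds are considered here, and "the series" means these few. Any claim that something is new, unique, unknown or untested is made for them only; others in the source may bear on it.

Of the compounds shown here, two have been measured in a functional assay on MCF7 cells (Homo sapiens) for antiproliferative activity, read by MTT assay, with a stated time of 72 h; a lower number here means a stronger inhibitor, a higher number a weaker inhibitor. Compound 1 `CC1=CC[C@H]2[C@H](CC[C@]2(C)O)C(C)(C)[C@@H]1CC[C@H]1[C@]2(C)CC[C@H](OC(=O)c3ccc(Cl)cc3)C(C)(C)O[C@H]2CC[C@@]1(C)O` gives 24100 nM, and compound 2 `CC1=CC[C@H]2[C@H](CC[C@]2(C)O)C(C)(C)[C@@H]1CC[C@H]1[C@]2(C)CC/C(=N/O)C(C)(C)O[C@H]2CC[C@@]1(C)O` gives 46800 nM; these two numbers lie within the scatter of each other, so neither stands apart. Compound 3 `CC1=CC[C@H]2[C@H](CC[C@]2(C)O)C(C)(C)[C@@H]1CC[C@H]1[C@]2(C)CC[C@H](OC(=O)c3cccc(C(F)(F)F)c3)C(C)(C)O[C@H]2CC[C@@]1(C)O` has not yet been measured. It differs from compound 1 in one place: 3-(trifluoromethyl)phenyl in place of 4-chlorophenyl on a carbonyl carbon. Going by the values given here, no measured pair here shows what such an exchange does, so only a small step is expected, likely none beyond the scatter. For compound 3 the expected value in this assay is 25000 nM, within a range from 8000 nM to 80000 nM. The expected step is a 1.0-fold higher number from compound 1 to compound 3 (0.02 log units; within the scatter).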

Compound 3, half-maximal inhibitory concentration: 37900 nM
Compound 3: the middle estimate sits 1.5-fold (0.18 log units) below what was measured; the range from low to high includes it.
By their numbers in this assay, from the lowest: compounds 1, 3 and 2 (each within the scatter of the next).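

The exchange of 4-chlorophenyl for 3-(trifluoromethyl)phenyl on this carbonyl carbon gives a 1.6-fold higher number from compound 1 to compound 3 (0.20 log units; within the scatter) in this assay. Going by these compounds alone, this is the first measured change at this place, and it shows that these two substituted aromatic groups cannot be told apart here, although the entering group has more heavy atoms. No measurement at hand bears on why the two read alike. As far as these compounds go, what an amine or a carboxylic acid on the aromatic ring would do stays open, as does a longer chain in place of the ring.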